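Furan to Methylpyrrole: Expected Affinity of Compound 4

The source may report more compounds than this note shows. Statements on the series, on what has been measured and on what is new or still open speak of the compounds shown alone.

Measured compounds and their values in an assay on cell membranes for binding affinity to adenosine receptor A1 (Cavia porcellus), read by radioligand binding; a lower number here means a stronger inhibitor, a higher number a weaker inhibitor:
compound 1, `CCCn1c(=O)c2nc(-c3nn[nH]n3)[nH]c2n(CCC)c1=O`, gives > 10000 nM, which is a limit of the assay and not a number.
compound 2, `CCCn1c(=O)c2nc(C(C)(O)CC)[nH]c2n(CCC)c1=O`, gives 240 nM.
compound 3, `CCCn1c(=O)c2nc(-c3ccco3)[nH]c2n(CCC)c1=O`, gives 560 nM.

Compound 3 stands at the highest of the two numbers shown; the step of a 2.3-fold higher number from compound 2 to compound 3 (0.37 log units; beyond the scatter) is modest but beyond the scatter. The value of compound 1 is only a limit (the limit of > 10000 nM in this assay, at which 1 of the 3 values shown sits), so the steps of an at least 41-fold lower number from compound 1 to compound 2 (1.61 log units; beyond the scatter) and an at least 17-fold lower number from compound 1 to compound 3 (1.25 log units; beyond the scatter) are known to be large in size but not exactly.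

Compound 4, `CCCn1c(=O)c2nc(-c3cccn3C)[nH]c2n(CCC)c1=O`, differs from compound 3 in one place: 1-methyl-1H-pyrrol-2-yl in place of furan-2-yl on an aromatic carbon. Both groups are five-membered aromatic rings with one hetero atom and one hydrogen-bond acceptor, and the measured steps from compound 1 change far more than this. Going by the values given here, no measured step therefore points to a change beyond the scatter in this assay for this swap.

Compound 4 is expected to give about 500 nM, in the range 150 nM to 2000 nM. The expected step is a 1.1-fold lower number from compound 3 to compound 4 (0.05 log units; within the scatter), within the scatter.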

Compound 4, inhibition constant: 140 nM
For compound 4 the middle estimate is 3.6-fold (0.55 log units) above the measured one; measured number outside the range, below it.
By their numbers in this assay, from the lowest: compounds 4 and 2 (each within the scatter of the next); then compound 3. At a limit, above all of these: compound 1.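

In this assay, the step of a 4.0-fold lower number from compound 3 to compound 4 (0.60 log units; beyond the scatter) shows that this position, on an aromatic carbon between two ring nitrogen atoms, distinguishes 1-methyl-1H-pyrrol-2-yl from furan-2-yl, although each is a five-membered aromatic ring with 1 hetero atom and 1 hydrogen-bond acceptor. The step of a 1.7-fold lower number from compound 2 to compound 4 (0.23 log units; within the scatter) means that 1-methyl-1H-pyrrol-2-yl and the non-ring group 1-hydroxy-1-methylpropyl cannot be told apart here. The step of an at least 71-fold lower number from compound 1 to compound 4 (1.85 log units; beyond the scatter) is large, but it starts from a limit and not a number, so its full size cannot be read: the limit of > 10000 nM in this assay, at which 1 of the 4 values shown sits.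

The compounds shown do not separate the effect of the ring nitrogen from that of its methyl group, and a pyrrol-2-yl ring with a hydrogen in place of that methyl would bear on this. Going by these compounds, how a longer chain on that nitrogen, such as ethyl, would compare also remains open.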